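Carboxylic acid in place of the acetyl group

The source may report more compounds than this note shows. Statements on the series, on what has been measured and on what is new or still open speak of the compounds shown alone.

Two compounds of the series have a number in an assay for binding affinity to 17-beta-hydroxysteroid dehydrogenase type 1 (Homo sapiens), with a stated time of 20 min, tested at 1 uM (on this read-out lower numbers stand for less inhibition and higher numbers for more inhibition at the one concentration tested (going by the name of the read-out)), so far. Compound 1 `O=[N+]([O-])c1ccc(-c2ccc3c(O)cccc3c2)cc1` carries a nitro group and in this assay compound 1 gives 15%. Within the data shown here, compound 2 `CC(=O)c1ccc(-c2ccc3c(O)cccc3c2)cc1` carries an acetyl group in its place; in this assay compound 2 gives 16%, which is the higher of the two numbers, yet the only step between measured compounds, a number 1 percentage points higher from compound 1 to compound 2 (within the scatter), lies within the scatter, so nothing can be said about an order of the two.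

Compound 3 `O=C(O)c1ccc(-c2ccc3c(O)cccc3c2)cc1` is not yet measured. It differs from compound 2 in one place: hydroxy in place of methyl on a carbonyl carbon. The same difference, cut one bond further out, reads acetyl to carboxy. Among the measured compounds shown here, no measured step touches a carboxy group, and the one step in hand, from nitro to acetyl, did not move the read-out beyond the scatter. Nothing in the numbers therefore points to a step of any size in either direction, and a value near that of compound 2 is the expectation, with a broad range to cover the missing information.

For compound 3 in this assay the estimate is 14%, with a range from 2% to 30%. The expected step is a number 2 percentage points lower from compound 2 to compound 3 (within the scatter), within the scatter.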

Compound 3, a percentage reported as inhibition, at one concentration (the size of the read-out at that concentration, not a potency): < 10%
Compound 3 was reported as a limit (the forecaster's own chance of this, stated with the estimate: 5%); middle value at least 4 percentage points away from the limit.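

In this assay compound 3 gives < 10%, which is a limit of the assay and not a number: the limit of < 10% in this assay, at which 1 of the 3 values shown sits.

Hydroxy in place of methyl on the carbonyl carbon gives a number at least 6 percentage points lower from compound 2 to compound 3 (that floor lies within the scatter), and the wider change of group gives a number at least 5 percentage points lower from compound 1 to compound 3 (that floor lies within the scatter), so the true size of each step stays unfixed and could lie within the scatter or beyond it. Among these compounds, what this adds to the nitro and acetyl pair is a third group at the same aromatic carbon, the first with a carboxy group and the first whose result is a limit, and still no step at this place is printed as beyond the scatter.

Open, from the compounds shown here alone, is whether any group on this aromatic carbon moves the read-out beyond the scatter, a question that an amine, a primary amide or a methyl ester in the same place would address. The hydroxy group of the shared core is the same in all three compounds, so its part in the read-out cannot be read from them.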